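The source may report more compounds than this note shows. Statements on the series, on what has been measured and on what is new or still open speak of the compounds shown alone.

Three members of the series have numbers in an assay on Prostate gland (Oryctolagus cuniculus) for inhibition of Adrenergic receptor alpha-1 (Homo sapiens); a higher number here means weaker binding, a lower number tighter binding. Compound 1 `COc1ccccc1N1CCN(CCCOc2ccc(C(=O)Nc3ccccc3OCCCC(=O)O)cc2)CC1` gives 100 nM in this assay. Compound 2 `COc1ccccc1N1CCN(CCCCOc2ccc(C(=O)Nc3ccccc3OCCCC(=O)O)cc2)CC1` gives 79.4 nM in this assay, and the two values lie within the scatter of each other. Compound 3 `COc1ccccc1N1CCN(CCC(Oc2ccc(C(=O)Nc3ccccc3OCCCC(=O)O)cc2)c2cccc(C)c2)CC1` gives 251 nM in this assay, the highest number of the three, set beyond the scatter from both compound 1 and compound 2. Among the measured compounds shown here, the step of a 2.5-fold higher number from compound 1 to compound 3 (0.40 log units; beyond the scatter) is the only measured step that touches the chain carbon in question.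

Compound 4 `COc1ccccc1N1CCN(CCC(Oc2ccc(C(=O)Nc3ccccc3OCCCC(=O)O)cc2)c2ccc(CC(C)C)cc2)CC1` differs from compound 3 at that same place: 4-isobutylphenyl in place of 3-methylphenyl on a saturated chain carbon bound to an oxygen on an aromatic ring and a saturated chain carbon. For the measured compounds named here, no measured pair swaps one such aryl group for another; the sole bearing comes from the step from compound 1 to compound 3, where introducing an aryl group onto that chain carbon raised the number by a modest margin. Enlarging that group from 3-methylphenyl to 4-isobutylphenyl is a change of a different kind, and the precedent gives no direction for it. The expectation is therefore a step of no more than the modest size seen before, most likely a small rise, with a 1.4-fold higher number from compound 3 to compound 4 (0.14 log units; within the scatter) as the estimated step. Compound 4 is expected to give 350 nM in this assay, within a range of 120 nM to 1000 nM.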

Compound 4, dissociation constant: 2000 nM
Beside the measured number, compound 4's estimate is 5.7-fold (0.76 log units) below it, and the stated range ends below it.
By their numbers in this assay, from the lowest: compounds 2 and 1 (each within the scatter of the next); then compound 3; then compound 4.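

In this assay, the identity of the aryl group on this saturated chain carbon matters, not only its presence: exchanging 3-methylphenyl for 4-isobutylphenyl gives an 8.0-fold higher number from compound 3 to compound 4 (0.90 log units; beyond the scatter) and so moves the number further than adding the first aryl group did, which gave a 2.5-fold higher number from compound 1 to compound 3 (0.40 log units; beyond the scatter) in the earlier comparison. Among the compounds shown here, measured against hydrogen at the same carbon, 4-isobutylphenyl gives a 20-fold higher number from compound 1 to compound 4 (1.30 log units; beyond the scatter) and is the only step graded as large, which shows that the modest loss seen with 3-methylphenyl does not set the scale for this position. No available evidence accounts for this loss of binding.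

Compound 3 and compound 4 differ both in the alkyl group and in where it stands on the phenyl ring, so these two changes remain unseparated, and 4-methylphenyl or unsubstituted phenyl on this carbon would bear directly on that question. Also open, on these data alone, is whether an aryl group here carries the same cost with the longer chain of compound 2, and whether a polar aryl substituent such as a hydroxyl group or an amine would behave like these two hydrocarbon groups.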